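From Compound 2 to Compound 3

This account rests on a few compounds, and the source may have more. Where it says the series, first, only, none or still open, it means among the compounds named here.

Measured in a functional assay on SW-620 cells (Homo sapiens) for inhibition, read by MTT assay, with a stated time of 72 h; a lower number here means a stronger inhibitor, a higher number a weaker inhibitor:
Compound 1 `COc1cc(NC(C)CCCNC(=O)NNC(=O)Nc2cccc(Cl)c2)c2ncccc2c1`: 25000 nM
Compound 2 `COc1cc(NC(C)CCCNC(=O)NNC(=O)Nc2ccc(O)cc2)c2ncccc2c1`: > 100000 nM, a limit

Compound 2 stands at a limit of the assay and not at a number. Compound 3 `COc1cc(NC(C)CCCNC(=O)Nc2ccc(O)cc2)c2ncccc2c1` differs from it by 4-hydroxyphenyl in place of ((4-hydroxyphenyl)carbamoyl)amino on an amide-type nitrogen. Within the data shown here, the only measured step, an at least 4.0-fold higher number from compound 1 to compound 2 (0.60 log units; beyond the scatter), concerns a different change, so it bears only loosely and sets no size for this one. Among the measured compounds shown here, compound 1 at 25000 nM gives the sole number. A modest move toward a lower number is expected in this assay, estimated as an at least 2.0-fold lower number from compound 2 to compound 3 (0.30 log units; that floor lies within the scatter). Another limit remains possible for compound 3. Compound 3 is estimated at 50000 nM, with an expected range of 12000 nM to 100000 nM.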

Compound 3, half-maximal inhibitory concentration: 30000 nM
Estimate against measurement, compound 3: 1.7-fold (0.22 log units) above; the measured number falls inside the stated range.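

On the amide-type nitrogen, 4-hydroxyphenyl in place of ((4-hydroxyphenyl)carbamoyl)amino gives an at least 3.3-fold lower number from compound 2 to compound 3 (0.52 log units; beyond the scatter) in this assay. That step is only a floor, since compound 2 stands at a limit: the limit of > 100000 nM in this assay, at which 1 of the 3 values shown sits.

In place of ((3-chlorophenyl)carbamoyl)amino, the same group gives a 1.2-fold higher number from compound 1 to compound 3 (0.08 log units; within the scatter), so the two stand level despite differing in both the length of the group and its ring substituent. From the compounds shown here alone, what remains open is how compound 3 would read with an amine or a carboxylic acid in place of its hydroxyl on the ring.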